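Cycloalkyl amides on the shared core: three limits, one estimate

The source may report more compounds than this note shows. Statements on the series, on what has been measured and on what is new or still open speak of the compounds shown alone.

Compound 1 `O=C(C1CC(F)C1)N1CCc2nc(C#Cc3ccccc3)sc2C1` in an assay on HEK293 cells for negative allosteric modulation of metabotropic glutamate receptor 5 (Homo sapiens), read by FLIPR, with a stated time of 1 h (a lower number here means a stronger inhibitor, a higher number a weaker inhibitor), gives the limit > 10000 nM.
Compound 2 `O=C(C1CCCC1)N1CCc2nc(C#Cc3ccccc3)sc2C1` in this assay gives the limit > 10000 nM.
Compound 3 `O=C(C1CCCO1)N1CCc2nc(C#Cc3ccccc3)sc2C1` in this assay gives the limit > 10000 nM.

Compound 3 thus stands at the limit of this assay, and the two other values shown are limits as well, so nothing orders the three. The steps a step that the two limits leave unreadable from compound 1 to compound 2, a step that the two limits leave unreadable from compound 1 to compound 3 and a step that the two limits leave unreadable from compound 2 to compound 3 cannot be read, because all three values sit at the limit (the limit of > 10000 nM in this assay, at which 3 of the 3 values shown sit).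

Compound 4 `CC1CCC(C(=O)N2CCc3nc(C#Cc4ccccc4)sc3C2)CC1` differs from compound 3 in one place: 4-methylcyclohexyl in place of oxolan-2-yl on a carbonyl carbon. The measured steps bear on it only as a set of limits: every exchange of the group on the carbonyl carbon so far has left the value at the limit, and none gives a readable size or direction. The step that the limit leaves unreadable from compound 3 to compound 4 is therefore expected to be unreadable as well, with compound 4 most likely remaining at the limit.

Compound 4 is expected to give about 15000 nM in this assay, within 3000 nM to 60000 nM.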

Compound 4, half-maximal inhibitory concentration: > 10000 nM
Compound 4: no number, only a limit; the forecaster's own chance of this, stated with the estimate: 70%; the middle value is on the limit's open side.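

Compound 4, like compound 1, compound 2 and compound 3, gives only a limit, so no step among these compounds can be read: the limit of > 10000 nM in this assay, at which 4 of the 4 values shown sit.

The compounds shown leave open how strongly any of them inhibits in this assay and whether the group on the carbonyl carbon changes that value.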